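A chain length between two measured compounds

A few compounds are considered here, and "the series" means these few. Any claim that something is new, unique, unknown or untested is made for them only; others in the source may bear on it.

In a functional assay on HCT-116 cells (Homo sapiens) for inhibition, read by MTT assay, with a stated time of 48 h (on this read-out lower numbers stand for stronger inhibition and higher numbers for weaker inhibition), compound 2 `COc1ccc(N(C)c2nc(C)nc3ccccc23)cc1C(=O)OCCCCCC[Se]C#N` gives 1990 nM as the higher of two numbers, against compound 1 `COc1ccc(N(C)c2nc(C)nc3ccccc23)cc1C(=O)OCCC[Se]C#N` at 720 nM on the same read-out. Compound 3 `COc1ccc(N(C)c2nc(C)nc3ccccc23)cc1C(=O)OCCCCC[Se]C#N` differs from compound 2 at one place (a group of 3 heavy atoms (1 carbon, 1 nitrogen, 1 selenium; no ring) in place of a group of 4 heavy atoms (2 carbon, 1 nitrogen, 1 selenium; no ring), on a saturated chain carbon, five bonds along the chain from an oxygen next to a carbonyl group) and so carries a chain shorter than that of compound 2 but longer than that of compound 1. Among the measured compounds shown here, the one measured step bearing on this is modest, a 2.8-fold higher number from compound 1 to compound 2 (0.44 log units; beyond the scatter) as the chain grows, so only part of it should be undone. A smaller step towards a lower number is expected, a 1.4-fold lower number from compound 2 to compound 3 (0.15 log units; within the scatter) in this assay and so probably within the scatter. The expected value for compound 3 is 1400 nM (700 nM to 2800 nM).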

Compound 3, half-maximal inhibitory concentration: 551 nM
For compound 3 the middle estimate is 2.5-fold (0.40 log units) above the measured one; the measured number lies below the stated range.
By their numbers in this assay, from the lowest: compounds 3 and 1 (each within the scatter of the next); then compound 2.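

In this assay, shortening the chain of compound 2 by one carbon gives a 3.6-fold lower number from compound 2 to compound 3 (0.56 log units; beyond the scatter), so a single chain carbon can matter here. Compound 3 carries a longer chain than compound 1, yet the comparison gives a 1.3-fold lower number from compound 1 to compound 3 (0.12 log units; within the scatter), so compound 3 goes against any steady climb with chain length. Nothing measured here explains this behaviour. As far as these compounds go, how a shorter chain than that of compound 1, or a longer chain than that of compound 2, would behave stays open. So does the effect of a thiocyanate in place of the selenium-bearing end.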